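The compounds below may be only part of what the source reports. "The series", "measured", "known", "first", "only" and "open" are said of these compounds alone.

Measured so far:
compound 1, `COc1ccc2sc(NC(=O)CN3CCN(c4ccccc4)CC3)nc2c1`: 21.7%
compound 2, `O=C(CN1CCN(c2ccccc2)CC1)Nc1nc2cc([N+](=O)[O-])ccc2s1`: 34.8%

Both compounds were tested in a functional assay on the whole organism (strain Wistar) for inhibition, with Rattus norvegicus as the target, read by paw edema, with a stated time of 2 h, at a dose of 30 mg/kg; a higher number here means more inhibition at the dose given (going by the name of the read-out), a lower number less inhibition. Compound 1 stands lowest of the two numbers; its nearest neighbour is compound 2, reached by the step of a number 13.1 percentage points higher from compound 1 to compound 2 (beyond the scatter). That step is a change of nitro in place of methoxy on an aromatic carbon, so it touches a different part of the shared core than the change followed here.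

Compound 3, `COc1ccc2sc(NC(=O)CN3CCNCC3)nc2c1`, differs from compound 1 in one place: hydrogen in place of phenyl on an amine nitrogen in a ring. Among the measured compounds shown here, no measured pair shows what happens when the phenyl on the amine nitrogen in the ring is exchanged for hydrogen; the only measured step concerns the aromatic carbon and gives no guide to the ring nitrogen. With nothing pointing either way, the expectation for compound 3 in this assay is a number close to that of compound 1, with no step beyond the scatter. The step of a number 1.7 percentage points lower from compound 1 to compound 3 (within the scatter) is expected to be small. Compound 3 is therefore estimated at 20%, within a range from 5% to 38%.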

Compound 3, a percentage reported as inhibition, in the whole organism at one dose (the size of the read-out at that dose, not a potency): 2.17%
The estimate for compound 3 lay 17.8 percentage points above the measured number; the whole stated range lies above it.
By their numbers in this assay, from the lowest: compound 3; then compound 1; then compound 2.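

Exchanging the phenyl on the amine nitrogen in the ring for hydrogen gives a number 19.5 percentage points lower from compound 1 to compound 3 (beyond the scatter) in this assay, so this position clearly affects the result, which the earlier step on an aromatic carbon could not reveal. Compound 3 gives 2.17%, which means that little inhibition remains at this dose once the phenyl is gone, even though the rest of the molecule is the same as in compound 1. The information at hand offers nothing on why the number falls with this change.

This single pair cannot separate the role of an aromatic ring on that nitrogen from the role of any larger group there; a methyl group, a cyclohexyl ring or a benzyl group in the same place would help to tell these apart. From the compounds shown here alone, it also remains open whether a nitro group on the aromatic carbon, as in compound 2, would change the result when the ring nitrogen carries hydrogen.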